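The source may report more compounds than this note shows. Statements on the series, on what has been measured and on what is new or still open speak of the compounds shown alone.

Measured compounds:
- Compound 1 `CCOc1ccccc1OCCSC(=S)N[C@H]1CCOC1=O`: 28300 nM
- Compound 2 `CC(C)(C)c1ccc(/C=C/C(=O)c2ccc(OCC(=O)N[C@H]3CCOC3=O)cc2)cc1`: 6570 nM
- Compound 3 `O=C(CNc1ccc(Cl)cc1Cl)N[C@H]1CCOC1=O`: > 64000 nM

In a functional assay on DU-145 cells (Homo sapiens) for antiproliferative activity, read by MTT assay, with a stated time of 72 h (on this read-out higher numbers stand for weaker inhibition and lower numbers for stronger inhibition), compound 2 gives 6570 nM, the lowest of the two numbers, and compound 1 gives 28300 nM, a gap beyond the scatter. For compound 3 the assay reports only a limit, (the limit of > 64000 nM in this assay, at which 1 of the 3 values shown sits), so its place relative to compound 2 cannot be read.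

Compound 4 `O=C(COc1ccc(C(=O)/C=C/c2ccc(Br)cc2)cc1)N[C@H]1CCOC1=O` is not yet measured. It differs from compound 2 in one place: bromo in place of tert-butyl on an aromatic carbon.

Going by the values given here, with no measured pair showing a comparable swap, the size of the step can only be guessed. Compound 4 is expected to change little, the step of a 1.3-fold higher number from compound 2 to compound 4 (0.11 log units; within the scatter) likely within or near the scatter. Compound 4 is estimated at 8500 nM, between 3000 nM and 25000 nM.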

Compound 4, half-maximal inhibitory concentration: 51700 nM
Compound 4: middle estimate off by 6.1-fold (0.78 log units), on the low side; the whole stated range lies below it.
By their numbers in this assay, from the lowest: compound 2; then compounds 1 and 4 (each within the scatter of the next). At a limit, above all of these: compound 3.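

In this assay the swap from 4-(tert-butyl)phenyl to 4-bromophenyl brings a 7.9-fold higher number from compound 2 to compound 4 (0.90 log units; beyond the scatter) and so shows that this place, para to a large group, is not indifferent to the group it carries. The earlier compounds shown here, which differ in more than one place, could not show this. Nothing given here explains the change.

Still open, from the compounds shown here alone, is whether a methyl, a methoxy, an amine or a carboxylic acid at this place would read like tert-butyl or like bromo. One swap cannot settle that.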